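This account rests on a few compounds, and the source may have more. Where it says the series, first, only, none or still open, it means among the compounds named here.

Working notes on the series.

Compound 1, `O=C1[C@H]2[C@H](ON(c3ccccc3)[C@@H]2c2coc3ccc(F)cc3c2=O)C(=O)N1c1ccccc1`, gives 43500 nM in a functional assay on THP-1 cells (Homo sapiens) for inhibition, read by sulforhodamine B assay, with a stated time of 48 h; on this read-out higher numbers stand for weaker inhibition and lower numbers for stronger inhibition. Compound 2, `Cc1ccc2occ([C@@H]3[C@H]4C(=O)N(c5ccccc5)C(=O)[C@H]4ON3c3ccccc3)c(=O)c2c1`, carries a methyl in place of the fluoro on an aromatic carbon. In this assay compound 2 reaches only the limit > 60000 nM, not a number. The change is an at least 1.3-fold higher number from compound 1 to compound 2 (0.13 log units; that floor lies within the scatter); the floor of that step rests on (the limit of > 60000 nM in this assay, at which 1 of the 2 values shown sits).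

Compound 3, `O=C1[C@H]2[C@H](ON(c3ccccc3)[C@@H]2c2coc3ccc(Br)cc3c2=O)C(=O)N1c1ccccc1`, differs from compound 2 by bromo in place of methyl on an aromatic carbon. For the measured compounds named here, the only measured step that bears on it is the one from compound 1 to compound 2, where a fluoro was exchanged for a methyl; here a methyl gives way to a bromo, so the one measured step points back toward compound 1, but its floor lies within the scatter and gives no firm direction. Compound 3 is therefore expected near the number of compound 1, the expected step being an at least 1.2-fold lower number from compound 2 to compound 3 (0.07 log units; that floor lies within the scatter), with the estimate for compound 3 at 50000 nM and a range from 20000 nM to 150000 nM.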

Compound 3, half-maximal inhibitory concentration: 22300 nM
The estimate for compound 3 lay 2.2-fold (0.35 log units) above the measured number, and the stated range covers the measured number.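

On this position, meta to a fused ring and para to a fused ring, bromo in place of methyl gives a step beyond the scatter in this assay, which the earlier step could not establish: an at least 2.6-fold lower number from compound 2 to compound 3 (0.42 log units; beyond the scatter). The size of that step is only a floor, and it rests on one limit: the limit of > 60000 nM in this assay, at which 1 of the 3 values shown sits. The two halogens do not separate, since the remaining step lies within the scatter, so bromo and fluoro cannot be told apart here: a 2.0-fold lower number from compound 1 to compound 3 (0.29 log units; within the scatter).

Still open, on these data alone, is how an amine, a carboxylic acid or a methoxy group on this aromatic carbon would read, and whether chloro would match fluoro and bromo. The compounds shown also leave open how the number responds to changes elsewhere on the shared core.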